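Swapping the Bicyclic Partner on the Carbonyl Carbon

A few compounds are considered here, and "the series" means these few. Any claim that something is new, unique, unknown or untested is made for them only; others in the source may bear on it.

Of the compounds shown here, three have so far been measured in an assay for inhibition of Nicotinamide phosphoribosyltransferase (Homo sapiens), read by mass spectrometry, with stated times of 15 min and 30 min; a lower number here means a stronger inhibitor, a higher number a weaker inhibitor. Compound 1 `O=C(NCc1ccc(S(=O)(=O)c2cc(F)cc(F)c2)cc1)c1cc2ccncc2o1` gives 14 nM. Compound 2 `O=C(NCc1ccc(S(=O)(=O)N2CCCCC2)cc1)c1ccn2cncc2c1` gives 1700 nM, and compound 3 `O=C(NCc1ccc(S(=O)(=O)N2CCCCC2)cc1)c1cc2ccncc2[nH]1` gives 1000 nM. On these numbers compound 3 stands second highest of the three: its nearest neighbour is compound 2, with the step of a 1.7-fold lower number from compound 2 to compound 3 (0.23 log units; within the scatter) lying within the scatter, while compound 1 sits far lower, beyond the scatter.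

Compound 4 `O=C(NCc1ccc(S(=O)(=O)N2CCCCC2)cc1)c1cc2ccncc2o1` differs from compound 3 by a group of 9 heavy atoms (7 carbon, 1 nitrogen, 1 oxygen; one five-membered aromatic ring with 1 hetero atom, one six-membered aromatic ring with 1 hetero atom) in place of a group of 9 heavy atoms (7 carbon, 2 nitrogen; one five-membered aromatic ring with 1 hetero atom, one six-membered aromatic ring with 1 hetero atom), on a carbonyl carbon. Within the data shown here, one measured step touches the same position on the carbonyl carbon, a 1.7-fold lower number from compound 2 to compound 3 (0.23 log units; within the scatter), and it stayed within the scatter. Compound 1 carries the same entering group as compound 4, yet it also differs from compound 4 elsewhere in the molecule, so its low number cannot be assigned to the ring exchange alone. The step from compound 3 to compound 4 is therefore expected to be modest, most likely downward, as a 2.0-fold lower number from compound 3 to compound 4 (0.30 log units; within the scatter). Compound 4 is estimated at 500 nM, with a range from 150 nM to 1500 nM.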

Compound 4, half-maximal inhibitory concentration: 40 nM
For compound 4 the middle estimate is 13-fold (1.10 log units) above the measured one, and the stated range ends above it.
By their numbers in this assay, from the lowest: compound 1; then compound 4; then compounds 3 and 2 (each within the scatter of the next).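

In this assay the position on the carbonyl carbon had shown only a 1.7-fold lower number from compound 2 to compound 3 (0.23 log units; within the scatter) and now shows a 25-fold lower number from compound 3 to compound 4 (1.40 log units; beyond the scatter) and a 43-fold lower number from compound 2 to compound 4 (1.63 log units; beyond the scatter) when the entering group, with 0 hydrogen-bond donors and 2 hydrogen-bond acceptors, takes the place of either earlier partner, so this position is not indifferent to the group it carries. With that group held constant, piperidin-1-yl in place of 3,5-difluorophenyl on a sulfonyl sulfur gives a 2.9-fold higher number from compound 1 to compound 4 (0.46 log units; beyond the scatter) and stands as a modest change beside those large steps, which means that the low number of compound 1 is not tied to 3,5-difluorophenyl alone. Nothing available explains why the exchange on the carbonyl carbon has so large an effect.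

The compounds shown leave open whether the exchange on the carbonyl carbon keeps its size when 3,5-difluorophenyl sits on the sulfonyl sulfur, since only compounds with piperidin-1-yl carry the two partners that leave. They also leave open how the number would respond to a sulfur atom in place of the oxygen of the entering group, or to morpholin-4-yl or dimethylamino on the sulfonyl sulfur.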